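Meta substituent swap on compound 3: isopropyl to trifluoromethyl

The compounds below may be only part of what the source reports. "The series", "measured", "known", "first", "only" and "open" are said of these compounds alone.

The series varies the aryl group on a saturated ring carbon of a shared core. Compound 1 `CC1=C(C(=O)OCC2CCN(C(=O)OC(C)(C)C)CC2)C(c2cccc(C#N)c2)C2=C(CC(C)(C)CC2=O)N1` carries 3-cyanophenyl, and in an assay on HEK293 cells for inhibition of neurogenic locus notch homolog protein 1 (Homo sapiens), read by a luciferase reporter and resazurin assay, with a stated time of 16 h (a lower number here means a stronger inhibitor, a higher number a weaker inhibitor), compound 1 gives 220 nM. Compound 2 `CC1=C(C(=O)OCC2CCN(C(=O)OC(C)(C)C)CC2)C(c2cc(Cl)cc(Cl)c2)C2=C(CC(C)(C)CC2=O)N1` carries 3,5-dichlorophenyl; in this assay compound 2 gives 640 nM. Compound 3 `CC1=C(C(=O)OCC2CCN(C(=O)OC(C)(C)C)CC2)C(c2cccc(C(C)C)c2)C2=C(CC(C)(C)CC2=O)N1` carries 3-isopropylphenyl; in this assay compound 3 gives 3320 nM, the highest of the three numbers, with a 15-fold higher number from compound 1 to compound 3 (1.18 log units; beyond the scatter) and a 5.2-fold higher number from compound 2 to compound 3 (0.71 log units; beyond the scatter).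

Compound 4 `CC1=C(C(=O)OCC2CCN(C(=O)OC(C)(C)C)CC2)C(c2cccc(C(F)(F)F)c2)C2=C(CC(C)(C)CC2=O)N1` differs from compound 3 by trifluoromethyl in place of isopropyl on an aromatic carbon. For the measured compounds named here, the steps that bear on this are the two leading into compound 3: a 15-fold higher number from compound 1 to compound 3 (1.18 log units; beyond the scatter) shows that exchanging the group on this aromatic carbon moves the number far, and a 5.2-fold higher number from compound 2 to compound 3 (0.71 log units; beyond the scatter) shows a modest move when the whole aryl ring changes. Both point the same way: the isopropyl compound sits highest, so removing isopropyl is expected to lower the number. Nothing measured here says whether trifluoromethyl lands near the cyano case or near the dichloro case. A modest downward step is therefore expected, a 4.2-fold lower number from compound 3 to compound 4 (0.62 log units; beyond the scatter). Compound 4 is estimated at 800 nM, with a range of 300 nM to 2500 nM.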

Compound 4, half-maximal inhibitory concentration: 760 nM
The estimate for compound 4 lay 1.1-fold (0.02 log units) above the measured number, within the range that was stated.
By their numbers in this assay, from the lowest: compound 1; then compounds 2 and 4 (each within the scatter of the next); then compound 3.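

Replacing isopropyl with trifluoromethyl on this aromatic carbon in this assay gives a 4.4-fold lower number from compound 3 to compound 4 (0.64 log units; beyond the scatter), so the high number seen with isopropyl does not carry over to every non-cyano group here. Trifluoromethyl alone matches the 3,5-dichlorophenyl ring, with a 1.2-fold higher number from compound 2 to compound 4 (0.07 log units; within the scatter), yet it does not reach the nitrile, with a 3.5-fold higher number from compound 1 to compound 4 (0.54 log units; beyond the scatter), which leaves the 3-cyanophenyl compound with the lowest number of the four, beyond the scatter against each of the others. No measurement on hand accounts for these differences.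

On these data alone, it remains open whether other groups on this aromatic carbon, such as an amine, a carboxylic acid, a primary amide or a methoxy group, would fall near the nitrile or near trifluoromethyl. As far as these compounds go, the effect of moving the nitrile or trifluoromethyl to another carbon of the aromatic ring is also open.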